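From Methoxy to Ethoxy on the Shared Core

The source may hold more compounds than are shown below. What is called first, only, known or untested is meant among the compounds shown, and "the series" means these compounds.

Measured in a functional assay on BGC-823 cells (Homo sapiens) for cytotoxicity, read by MTT assay, with a stated time of 24 h; on this read-out lower numbers stand for stronger inhibition and higher numbers for weaker inhibition:
- Compound 1 `CC(C)c1cc2c(cc1O)[C@]13CCC[C@](C)(CO[C@H]1O)[C@@H]3CC2`: > 10000 nM, a limit
- Compound 2 `CO[C@@H]1OC[C@@]2(C)CCC[C@@]13c1cc(O)c(C(C)C)cc1CC[C@@H]23`: > 10000 nM, a limit
- Compound 3 `CCO[C@@H]1OC[C@@]2(C)CCC[C@@]13c1cc(O)c(C(C)C)cc1CC[C@@H]23`: not yet measured

Compound 2 stands at > 10000 nM, which is a limit. The change to compound 3 is methyl in place of hydrogen on a saturated chain carbon bound to an oxygen on a saturated carbon, methoxy to ethoxy. Among the compounds with values here, the only measured step that bears on it is a step that the two limits leave unreadable from compound 1 to compound 2, and it also places a methyl on an oxygen on a saturated carbon. Both measured compounds sit at the limit of > 10000 nM in this assay, at which 2 of the 2 values shown sit. No readable shift is therefore expected in this assay, and no direction can be claimed. The expected step is a step that the limit leaves unreadable from compound 2 to compound 3. For compound 3 the estimate is 15000 nM. The expected range for compound 3 runs from 7000 nM to 40000 nM.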

Compound 3, half-maximal inhibitory concentration: > 10000 nM
Compound 3 gave a limit, no number; the forecaster's own chance of this, stated with the estimate: 80%; the middle value lies beyond the limit too.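

In this assay compound 3 gives > 10000 nM, a limit, so no step among compound 1, compound 2 and compound 3 can be read: the limit of > 10000 nM in this assay, at which 3 of the 3 values shown sit.

The compounds shown leave open whether methoxy to ethoxy shifts the read-out at all.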